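Compound 1 to compound 3: dimethylamino against propylamino

The compounds below may be only part of what the source reports. "The series", "measured", "known", "first", "only" and "open" are said of these compounds alone.

Measured so far in an ADME assay on HFF cells (Homo sapiens) for cytotoxicity, with a stated time of 8 days; a higher number here means that more compound is tolerated, a lower number that less compound is tolerated
- compound 1 `CN(C)c1nc(N)nc2c1ncn2/C=C1/CC1(CO)CO` gives > 300000 nM
- compound 2 `Nc1nc2c(ncn2/C=C2/CC2(CO)CO)c(=O)[nH]1` gives > 300000 nM

Compound 1 stands at a limit: in this assay compound 1 gives > 300000 nM and this is a limit, not a number. Compound 2 reads > 300000 nM and that is also a limit. Among the measured compounds shown here, the record therefore amounts to the limit of > 300000 nM in this assay, at which 2 of the 2 values shown sit, and no measured step links two compounds that differ in one place.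

Compound 3 `CCCNc1nc(N)nc2c1ncn2/C=C1/CC1(CO)CO` has propylamino in place of dimethylamino on an aromatic carbon of the shared core (propylamino in place of dimethylamino on an aromatic carbon). The site lies opposite the ring nitrogen and meta to an amino group. For the measured compounds named here, with no measured step to draw on, the expectation rests on the two limits alone and stays cautious.

The estimated at least 1.2-fold lower number from compound 1 to compound 3 (0.07 log units; that floor lies within the scatter) is expected to stay within the scatter, and to run downward if it shows at all. For compound 3 the expected half-maximal cytotoxic concentration in this assay is 250000 nM, with an estimated range from 100000 nM to 300000 nM and a fair chance that only a limit is reported.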

Compound 3, half-maximal cytotoxic concentration: > 300000 nM
Compound 3 gave a limit, no number; the forecaster's own chance of this, stated with the estimate: 60%; middle value at least 1.2-fold (0.07 log units) from the limit.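

In this assay compound 3 gives > 300000 nM, a limit and not a number. Compound 1 gives > 300000 nM, also a limit, so the step from compound 1 to compound 3 cannot be read. The compounds shown leave open the actual half-maximal cytotoxic concentration of each one, and the record rests on a single reading: the limit of > 300000 nM in this assay, at which 3 of the 3 values shown sit.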